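Lengthening the bromoalkoxy chain in an antiproliferative series

The compounds below may be only part of what the source reports. "The series", "measured", "known", "first", "only" and "open" are said of these compounds alone.

In a functional assay on MDA-MB-231 cells (Homo sapiens) for antiproliferative activity, read by MTT assay, with a stated time of 48 h (a higher number here means a weaker inhibitor, a lower number a stronger inhibitor), compound 1 (`COc1ccc(N(C)c2ccnc(Cl)n2)cc1O`) gives 833 nM and compound 2 (`COc1ccc(N(C)c2ccnc(Cl)n2)cc1OCCBr`) gives 6620 nM as the higher of the two numbers. In compound 3 (`COc1ccc(N(C)c2ccnc(Cl)n2)cc1OCCCCBr`), still unmeasured, 2-bromoethoxy gives way to 4-bromobutoxy (2-bromoethyl in place of bromo on a saturated chain carbon, two bonds along the chain from an oxygen on an aromatic ring). Among the compounds with values here, the one measured step bearing on this is a 7.9-fold higher number from compound 1 to compound 2 (0.90 log units; beyond the scatter) with 2-bromoethyl in place of hydrogen on an oxygen on an aromatic ring. That step added the chain rather than lengthening it, so it sets no direction, and no step beyond the scatter is expected in this assay here. Compound 3 is estimated at 6000 nM within an expected range of 1800 nM to 20000 nM overall. The expected change is a 1.1-fold lower number from compound 2 to compound 3 (0.04 log units; within the scatter) in this estimate.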

Compound 3, half-maximal inhibitory concentration: 992 nM
Estimate against measurement, compound 3: 6.0-fold (0.78 log units) above; the measured number lies below the stated range.
By their numbers in this assay, from the lowest: compounds 1 and 3 (each within the scatter of the next); then compound 2.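

In this assay the length of the chain on this oxygen proves to matter, with a 6.7-fold lower number from compound 2 to compound 3 (0.82 log units; beyond the scatter) as 2-bromoethoxy gives way to 4-bromobutoxy. The penalty seen with the shorter chain therefore does not carry over to the longer one: set against the hydroxyl, the longer chain shows a 1.2-fold higher number from compound 1 to compound 3 (0.08 log units; within the scatter) and so loses nothing beyond the scatter. No measurement here explains why the two chains differ.

As far as these compounds go, it remains open how a 3-bromopropoxy chain or a still longer chain would behave. Also open, from the compounds shown here alone, is whether the bromine itself matters, which an amine or a hydroxyl at the end of the chain in its place would test.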